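Tail variation on a diaryl-propanoic acid series

The source may report more compounds than this note shows. Statements on the series, on what has been measured and on what is new or still open speak of the compounds shown alone.

Measured compounds and values in a functional assay on HEK293 cells for agonist activity at Free fatty acid receptor 1 (Homo sapiens), read by calcium flux; a lower number here means that less compound is needed, a higher number that more compound is needed for the effect:
- compound 1 `CCCOc1ccc(C(CC(=O)O)c2ccccc2)cc1`: 4.8 uM
- compound 2 `CCCCCCOc1ccc(C(CC(=O)O)c2ccccc2)cc1`: 2.88 uM
- compound 3 `O=C(O)CC(c1ccccc1)c1ccc(OCCCC(F)(F)F)cc1`: 3.16 uM

Compound 3 stands second highest of the three numbers in this assay. Its nearest neighbour is compound 2, with a 1.1-fold higher number from compound 2 to compound 3 (0.04 log units; within the scatter), and its furthest is compound 1, with a 1.5-fold lower number from compound 1 to compound 3 (0.18 log units; within the scatter). Both steps sit within the scatter, so no order among the three can be read.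

The next compound, compound 4 `C=C(C)CCOc1ccc(C(CC(=O)O)c2ccccc2)cc1`, differs from compound 3 by 1-methylethenyl in place of 2,2,2-trifluoroethyl on a saturated chain carbon, two bonds along the chain from an oxygen on an aromatic ring. The bearing steps are all changes at the same end of the chain: a 1.7-fold lower number from compound 1 to compound 2 (0.22 log units; within the scatter), a 1.5-fold lower number from compound 1 to compound 3 (0.18 log units; within the scatter) and a 1.1-fold higher number from compound 2 to compound 3 (0.04 log units; within the scatter). None of these reaches beyond the scatter, whether a propyl, a trifluoromethyl or only hydrogen ends the chain. The shared core and the acid are untouched in every case.

On that basis the step into compound 4 in this assay is expected to be small, with no direction beyond the scatter, a 1.1-fold lower number from compound 3 to compound 4 (0.02 log units; within the scatter). Compound 4 is estimated at 3 uM, within a range from 1.5 uM to 6.5 uM.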

Compound 4, concentration for half-maximal effect: 2.71 uM
Estimate against measurement, compound 4: 1.1-fold (0.04 log units) above; measured number inside the range.
By their numbers in this assay, from the lowest: compounds 4, 2, 3 and 1 (each within the scatter of the next).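

Notes on the tail end: in this assay the change from 2,2,2-trifluoroethyl to 1-methylethenyl gives a 1.2-fold lower number from compound 3 to compound 4 (0.07 log units; within the scatter) and so removes all the fluorine and puts in a double bond outside aromatic rings, with 3 heavy atoms entering where 5 leave. Set against the other tails, the same end gives a 1.1-fold lower number from compound 2 to compound 4 (0.03 log units; within the scatter) and a 1.8-fold lower number from compound 1 to compound 4 (0.25 log units; within the scatter), so all three new steps stay within the scatter and no order can be read among the four compounds. The earlier compounds showed only saturated chain ends, whereas this position, on a saturated chain carbon two bonds along the chain from an oxygen on an aromatic ring, now also carries an end with a double bond and still shows no step beyond the scatter; no supporting data are available to explain this reading.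

The compounds shown leave open whether a terminal amine, a hydroxyl group or a phenyl ring at the chain end would produce a step beyond the scatter. They also leave open whether the tails would still read alike with an amide in place of the carboxylic acid of the shared core.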